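A few compounds are considered here, and "the series" means these few. Any claim that something is new, unique, unknown or untested is made for them only; others in the source may bear on it.

Values in an ADME assay on HEK293 cells (Homo sapiens) for cytotoxicity, read by MTT assay, with a stated time of 48 h (on this read-out lower numbers stand for stronger inhibition and higher numbers for weaker inhibition), are as follows:
- Compound 1 `CCn1c(N)c(-c2nc3ccccc3[nH]2)c2nc(C#N)c(C#N)nc21` gives > 50000 nM (a limit of the assay)
- Compound 2 `CCN(CC)CCn1c(N)c(-c2nc3ccccc3[nH]2)c2nc(C#N)c(C#N)nc21` gives 12200 nM
- Compound 3 `CCCn1c(N)c(-c2nc3ccccc3[nH]2)c2nc(C#N)c(C#N)nc21` gives > 50000 nM (a limit of the assay)

Within the data shown here, compound 2 with 12200 nM holds the only true number here. The other two compounds stand at the limit of > 50000 nM in this assay, at which 2 of the 3 values shown sit, and so carry no number.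

The unmeasured compound 4 `CCN(CC)CCn1c(N)c(-c2nc3ccccc3n2C)c2nc(C#N)c(C#N)nc21` keeps the diethylamino group of compound 2 and alters one place, as counted in methyl in place of hydrogen on an aromatic nitrogen.

The measured steps all lie on the chain. Both an at least 4.0-fold lower number from compound 1 to compound 2 (0.61 log units; beyond the scatter) and an at least 4.0-fold higher number from compound 2 to compound 3 (0.61 log units; beyond the scatter) are beyond the scatter, while a step that the two limits leave unreadable from compound 1 to compound 3 adds nothing further. None of them tests the aromatic nitrogen, so none gives a size for this methyl. Compound 4 keeps the group that enters in an at least 4.0-fold lower number from compound 1 to compound 2 (0.61 log units; beyond the scatter) and is therefore expected to stay close to compound 2 in this assay with no step beyond the scatter in either direction. The expected outcome is a 1.1-fold higher number from compound 2 to compound 4 (0.06 log units; within the scatter) on this estimate. For compound 4 the estimate is 14000 nM with 5000 nM to 40000 nM as the expected range.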

Compound 4, half-maximal inhibitory concentration: 25400 nM
Compound 4: middle estimate off by 1.8-fold (0.26 log units), on the low side, within the range that was stated.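

In this assay, methyl in place of hydrogen on the aromatic nitrogen, which turns 1H-benzimidazol-2-yl into 1-methyl-1H-benzimidazol-2-yl, gives a 2.1-fold higher number from compound 2 to compound 4 (0.32 log units; beyond the scatter). Among these compounds, this is the first readable change away from the chain, and it shows that this nitrogen also affects the read-out: adding a single carbon, with no ring and no net charge, moves the number modestly towards weaker inhibition. Compound 4 keeps the diethylamino group and gives a true number, 25400 nM, yet this rests on one pair, and compound 2 is the only earlier compound that offers a numerical comparison: the limit of > 50000 nM in this assay, at which 2 of the 4 values shown sit.

As far as these compounds go, what remains open is whether the same methyl would have any readable effect in compound 1 or compound 3, which lack the diethylamino group, and so whether the step depends on that group. From the compounds shown here alone, it is also open how a larger group on this nitrogen, such as ethyl or benzyl, or a different amine at the end of the chain, such as morpholine or piperidine, would change the number.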